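Methyl removal carried over to a core at the limit

The source may hold more compounds than are shown below. What is called first, only, known or untested is meant among the compounds shown, and "the series" means these compounds.

Compound 1, `CC/C=C\C/C=C\C/C=C\CCCCCCCc1cc(=O)c2c(O)cc(OCOC)c(C)c2o1`: in a functional assay on MDA-MB-231 cells (Homo sapiens) for antiproliferative activity, read by MTT assay (on this read-out higher numbers stand for weaker inhibition and lower numbers for stronger inhibition), compound 1 gives 6790 nM.
Compound 2, `CC/C=C\C/C=C\C/C=C\CCCCCCCc1cc(=O)c2c(O)c(C)c(OCOC)c(C)c2o1`: in this assay compound 2 gives 16100 nM.
Compound 3, `CCCCCCCCCCCCCCCc1cc(=O)c2c(O)c(C)c(O)c(C)c2o1`: in this assay compound 3 gives only a limit of the assay, > 87000 nM.

Among the measured compounds shown here, the one counted step between measured compounds is hydrogen in place of methyl on an aromatic carbon, which gave a 2.4-fold lower number from compound 2 to compound 1 (0.37 log units; beyond the scatter). Compound 4, `CCCCCCCCCCCCCCCc1cc(=O)c2c(O)cc(O)c(C)c2o1`, differs from compound 3 by hydrogen in place of methyl on an aromatic carbon; this is the same kind of change, but here the carbon is ortho to two hydroxy groups, whereas in compound 2 it is ortho to a hydroxy group and ortho to a methoxymethoxy group. How the core of compound 3 differs from the core of compound 2 is not broken down here. Compound 3 sits at the limit of > 87000 nM in this assay, at which 1 of the 3 values shown sits, so no measured number anchors the new step. From compound 3 to compound 4 a step of about an at least 1.4-fold lower number from compound 3 to compound 4 (0.16 log units; that floor lies within the scatter) is expected, resting on the earlier step of this kind. Compound 4 is therefore estimated at 60000 nM, between 20000 nM and 200000 nM, with a real chance that only a limit is reported again.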

Compound 4, half-maximal inhibitory concentration: 6790 nM
Estimate against measurement, compound 4: 8.8-fold (0.95 log units) above; the measured number lies below the stated range.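

In this assay hydrogen in place of methyl on an aromatic carbon gives an at least 12-fold lower number from compound 3 to compound 4 (1.10 log units; beyond the scatter) and so runs the same way as on the earlier core, yet the change does not carry over at one size: the same change on two cores in this assay, a 2.4-fold lower number (0.37 log units; beyond the scatter) from compound 2 to compound 1 and an at least 12-fold lower number (1.10 log units; beyond the scatter) from compound 3 to compound 4, at least 5.4-fold (0.73 log units) apart, beyond the scatter of two such steps.
Compound 3 gives only a limit of the assay, > 87000 nM, so the new step is a floor and not a measured size.
The two pairs differ from each other in more than one place, so the gap is not tied to any single feature of the cores.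

Still open, on these data alone, is how an ethyl group or an amine on that aromatic carbon would compare with hydrogen and methyl on either core. Also open, as far as these compounds go, is whether a third core would follow the smaller step or the larger one.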